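The compounds below may be only part of what the source reports. "The series", "measured", "known", "first", "only" and "open" are said of these compounds alone.

Compound 3 `Cc1cc(C(=O)c2cccc(Br)c2)ccc1OCC(=O)Nc1nc(-c2ccccc2)cs1` gives 23800 nM in a functional assay on DLA cells (Mus musculus) for cytotoxicity, read by MTT assay, with a stated time of 48 h; on this read-out higher numbers stand for weaker inhibition and lower numbers for stronger inhibition. Its nearest companion is compound 1 `Cc1cc(C(=O)c2ccccc2)ccc1OCC(=O)Nc1nc(-c2ccccc2)cs1`, which gives 22300 nM in this assay, and the furthest is compound 2 `Cc1ccc(C(=O)c2ccc(OCC(=O)Nc3nc(-c4ccccc4)cs3)c(C)c2)cc1`, which gives 26400 nM; all three numbers sit within the scatter of one another, as the steps of a 1.1-fold higher number from compound 1 to compound 3 (0.03 log units; within the scatter) and a 1.1-fold lower number from compound 2 to compound 3 (0.05 log units; within the scatter) show.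

Compound 4 `Cc1cc(C(=O)c2ccccc2C)ccc1OCC(=O)Nc1nc(-c2ccccc2)cs1` differs from compound 3 by one change: 2-methylphenyl in place of 3-bromophenyl on a carbonyl carbon. Within the data shown here, two measured steps bear on this. The step of a 1.2-fold higher number from compound 1 to compound 2 (0.07 log units; within the scatter) shows that adding a methyl on an aromatic carbon of this phenyl left the number where it was, and the step of a 1.1-fold lower number from compound 2 to compound 3 (0.05 log units; within the scatter) shows that exchanging 4-methylphenyl for 3-bromophenyl on the carbonyl carbon did the same. Nothing measured here separates the positions of a methyl on that ring.

Compound 4 is therefore expected to show no step beyond the scatter, a 1.0-fold lower number from compound 3 to compound 4 (0.01 log units; within the scatter). The number of compound 4 in this assay is estimated at 23000 nM, with a range from 12000 nM to 45000 nM.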

Compound 4, half-maximal inhibitory concentration: 23100 nM
Compound 4: the middle estimate sits 1.0-fold (0.00 log units) below what was measured, and the stated range covers the measured number.
By their numbers in this assay, from the lowest: compounds 1, 4, 3 and 2 (each within the scatter of the next).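

Among these compounds, on the carbonyl carbon, 2-methylphenyl reads like 3-bromophenyl, with a 1.0-fold lower number from compound 3 to compound 4 (0.01 log units; within the scatter), and the pair of compound 2 and compound 4 gives the first comparison of two methyl placements on this ring, with a 1.1-fold lower number from compound 2 to compound 4 (0.06 log units; within the scatter). Against the plain phenyl, the new methyl placement also stays within the scatter, with a 1.0-fold higher number from compound 1 to compound 4 (0.02 log units; within the scatter), so none of the four groups on this carbonyl carbon separates from another in this assay. No evidence is given that would explain this result.

As far as these compounds go, it remains open whether an amine, a carboxylic acid or a methoxy group on this ring would give a step beyond the scatter. The compounds shown also leave open whether changes elsewhere on the shared core, such as on its other phenyl, would do so.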